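The compounds below may be only part of what the source reports. "The series", "measured", "known", "first", "only" and "open" are said of these compounds alone.

Two compounds share one core and differ only in the group carried on an aromatic carbon of a six-membered aromatic ring of carbon only. Compound 1 `O=[N+]([O-])c1cccc(CNc2cc(C(F)(F)F)cc3[nH]ncc23)c1` carries a nitro group, and in an assay for inhibition of Tryptophan 2,3-dioxygenase (Homo sapiens), with stated times of 10 min and 60 min, tested at 100 uM (a higher number here means a stronger effect of the compound at the concentration tested, a lower number a weaker effect), compound 1 gives 82%. Compound 2 `O=C(O)CNc1cccc(CNc2cc(C(F)(F)F)cc3[nH]ncc23)c1` carries a (carboxymethyl)amino group instead, and in this assay compound 2 gives 65%. The measured step shows a number 17 percentage points lower from compound 1 to compound 2 (beyond the scatter), so compound 2 stands as the lower of the two numbers seen so far.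

Compound 3 `FC(F)(F)c1cccc(CNc2cc(C(F)(F)F)cc3[nH]ncc23)c1` is a further variation at the same aromatic carbon: trifluoromethyl in place of (carboxymethyl)amino on an aromatic carbon. Among the measured compounds shown here, only one measured step bears on this change, and it is a different swap, so the guide is thin. It does show that exchanging the group at this carbon moves the read-out modestly, and that compound 1, which lacks the (carboxymethyl)amino group, gives the higher number. A move back toward that level is therefore expected for compound 3. For compound 3 in this assay, the estimate is 78%, within a range of 60% to 92%. This corresponds to an expected step of a number 13 percentage points higher from compound 2 to compound 3 (beyond the scatter).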

Compound 3, a percentage reported as inhibition, at one concentration (the size of the read-out at that concentration, not a potency): 74%
Estimate against measurement, compound 3: 4 percentage points above; low and high end bracket the measured number.
By their numbers in this assay, from the lowest: compounds 2, 3 and 1 (each within the scatter of the next, the first and the last beyond it).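

At this aromatic carbon, trifluoromethyl in place of (carboxymethyl)amino gives a number 9 percentage points higher from compound 2 to compound 3 (within the scatter), and trifluoromethyl in place of nitro gives a number 8 percentage points lower from compound 1 to compound 3 (within the scatter). In this assay, trifluoromethyl therefore cannot be told apart from either of the other two groups, even though those two are separated by a number 17 percentage points lower from compound 1 to compound 2 (beyond the scatter), so the only clear difference among these three groups remains the one between nitro and (carboxymethyl)amino. Nothing measured here gives a reason for these numbers.

Open, from the compounds shown here alone, is how a plain amine, a carboxylic acid joined directly to the ring, a methyl group or a chlorine atom would read at this same carbon, and whether a longer chain ending in a carboxylic acid would read differently from (carboxymethyl)amino. Also open, going by these compounds, is how these compounds compare as true potencies, since each number is the size of the effect at a single tested concentration, and a full concentration series could separate groups that this read-out cannot.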